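The source may hold more compounds than are shown below. What is called first, only, known or untested is meant among the compounds shown, and "the series" means these compounds.

Measured so far:
- compound 1 `COc1ccc2nccc(C3CN(C4CCN(Cc5c[nH]c6ccccc56)CC4)C(=O)O3)c2c1`: < 50200 nM
- compound 2 `COc1ccc2nccc(C3CN(C4CCN(Cc5cccc(Cl)c5)CC4)C(=O)O3)c2c1`: 6310 nM

In an in vitro functional assay on RBL cells for antagonist activity at C-C chemokine receptor type 8 (Homo sapiens), read by FLIPR and calcium flux (a lower number here means a stronger inhibitor, a higher number a weaker inhibitor), compound 2 gives 6310 nM, the only number shown in the series. Compound 1 reaches only a limit of the assay, < 50200 nM (the limit of < 50200 nM in this assay, at which 1 of the 2 values shown sits). The step that the limit leaves unreadable from compound 1 to compound 2 therefore cannot be read in size.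

Compound 3 `COc1ccc(CN2CCC(N3CC(c4ccnc5ccc(OC)cc45)OC3=O)CC2)cc1` differs from compound 2 by 4-methoxyphenyl in place of 3-chlorophenyl on a saturated chain carbon bound to an amine nitrogen in a ring. For the measured compounds named here, no measured step bears on this change: the one step between measured compounds, a step that the limit leaves unreadable from compound 1 to compound 2, concerns a different replacement and its size is hidden by the limit. There is thus no basis in the numbers shown for expecting a step beyond the scatter in either direction in this assay.

Compound 3 is therefore estimated close to compound 2, at 6300 nM with a range of 1500 nM to 25000 nM, which amounts to an expected step of a 1.0-fold lower number from compound 2 to compound 3 (0.00 log units; within the scatter).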

Compound 3, half-maximal inhibitory concentration: 1260 nM
Compound 3: middle estimate off by 5.0-fold (0.70 log units), on the high side, outside the stated range (below it).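

The place on a saturated chain carbon bound to an amine nitrogen in a ring responds to the group it carries: 4-methoxyphenyl in place of 3-chlorophenyl gives a 5.0-fold lower number from compound 2 to compound 3 (0.70 log units; beyond the scatter) in this assay. For the compounds shown here, this is the first step whose size can be read, and it shows that a change at this place can move the number beyond the scatter. The steps from compound 1 cannot be read, since its value is a limit of the assay: the limit of < 50200 nM in this assay, at which 1 of the 3 values shown sits.

The change from compound 2 to compound 3 alters both the substituent and its printed ring position, so the two effects remain unseparated. 4-Chlorophenyl and 3-methoxyphenyl would separate them, while a carboxylic acid on the phenyl ring would test a substituent of a different kind.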